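The compounds below may be only part of what the source reports. "The series", "measured", "known", "first", "only" and "open" are said of these compounds alone.

Measured in a functional assay on RKOp27 cells (Homo sapiens) for cytotoxicity, read by MTT assay, with a stated time of 3 days; a higher number here means a weaker inhibitor, a lower number a stronger inhibitor:

Compound 1 `N#Cc1c(Nc2ccccc2)nc(SCc2nc3ccccc3[nH]2)nc1-c1ccccc1`: 4.9 nM
Compound 2 `CNc1nc(SCc2nc3ccccc3[nH]2)nc(-c2ccccc2)c1C#N`: 3.7 nM
Compound 3 `N#Cc1c(-c2ccccc2)nc(SCc2nc3ccccc3[nH]2)nc1N1CCNCC1`: 5.81 nM

The three compounds cannot be separated on these numbers. Compound 3, at 5.81 nM, lies within the scatter of both others, as shown by a 1.2-fold higher number from compound 1 to compound 3 (0.07 log units; within the scatter) and a 1.6-fold higher number from compound 2 to compound 3 (0.20 log units; within the scatter). The remaining pair gives a 1.3-fold lower number from compound 1 to compound 2 (0.12 log units; within the scatter), also within the scatter.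

The next compound is compound 4 `N#Cc1c(-c2ccccc2)nc(SCc2nc3ccccc3[nH]2)nc1N1CCN(S(=O)(=O)c2ccccc2[N+](=O)[O-])CC1`, which keeps the piperazine of compound 3 but carries (2-nitrophenyl)sulfonyl in place of hydrogen on an amine nitrogen in a ring.

The measured steps bear on this change only indirectly. All three exchange the group on one aromatic carbon, and none places a substituent on the ring nitrogen that changes here. They show that anilino, methylamino and piperazin-1-yl give similar numbers, but they do not test this substitution. No shift beyond the scatter is therefore expected in this assay, although the uncertainty is wide and leans towards a higher number.

The expected change is a 1.4-fold higher number from compound 3 to compound 4 (0.14 log units; within the scatter). For compound 4 the estimated value is 8 nM, with an expected range of 2 nM to 40 nM.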

Compound 4, half-maximal inhibitory concentration: 5.6 nM
Beside the measured number, compound 4's estimate is 1.4-fold (0.15 log units) above it; the range from low to high includes it.
By their numbers in this assay, from the lowest: compounds 2, 1, 4 and 3 (each within the scatter of the next).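

The earlier steps shown here all exchanged the group on one aromatic carbon, whereas this step places a substituent on the amine nitrogen of the piperazine ring itself, and in this assay it gives a 1.0-fold lower number from compound 3 to compound 4 (0.02 log units; within the scatter). The hydrogen on that nitrogen can therefore be replaced by (2-nitrophenyl)sulfonyl, a group of 12 heavy atoms that brings one six-membered aromatic ring, without the number leaving the scatter, so for this pair a free hydrogen on that nitrogen is not needed to keep the number in this range. Nothing available here accounts for why the number holds across so large an addition.

The compounds shown leave open whether this tolerance extends to other groups on the same nitrogen, such as a methyl, an acetyl, a benzyl or a chain ending in a carboxylic acid. They also leave open whether the nitro group and the sulfonyl link each matter separately, since the two enter together in compound 4 and a plain phenylsulfonyl group is not among the compounds shown.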